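Halogen Swap on a Phenoxy Ring and Cytotoxicity

The source may hold more compounds than are shown below. What is called first, only, known or untested is meant among the compounds shown, and "the series" means these compounds.

Of the compounds shown here, two with a shared core have so far been measured for cytotoxicity. Compound 1 `CC(CCNC(=O)c1c(Cl)cncc1Cl)N1CCC(C(=O)c2ccc(Br)cc2)CC1` gives 189000 nM in an ADME assay on PBMC cells (Homo sapiens) for cytotoxicity; on this read-out lower numbers stand for higher toxicity in this test and higher numbers for lower toxicity in this test. Compound 2 `CC(CCNC(=O)c1c(Cl)cncc1Cl)N1CCC(C(Oc2cccc(F)c2)c2ccc(C(F)(F)F)cc2)CC1` gives 5400 nM in this assay, which is the lowest of the two numbers; compound 1 sits at a markedly higher number, a gap beyond the usual scatter, so compound 2 is the more toxic of the pair in this read-out.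

Compound 3 `CC(CCNC(=O)c1c(Cl)cncc1Cl)N1CCC(C(Oc2ccccc2Cl)c2ccc(C(F)(F)F)cc2)CC1` has not yet been measured. It differs from compound 2 in a single place: 2-chlorophenyl in place of 3-fluorophenyl on an oxygen on a saturated carbon. Within the data shown here, no measured pair in this set shows what such a change does to cytotoxicity, so there is nothing to calibrate the step on. The exchange is small in size, one halogen on a phenoxy ring for another, and the expectation is a step of modest size, not beyond the scatter, if anything a slightly lower number.

Compound 3 is therefore expected to give about 4500 nM in this assay, with a likely range from 1500 nM to 13000 nM. The expected step of a 1.2-fold lower number from compound 2 to compound 3 (0.08 log units; within the scatter) is estimated to remain within the scatter of repeated measurements.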

Compound 3, half-maximal cytotoxic concentration: 4400 nM
Estimate against measurement, compound 3: 1.0-fold (0.01 log units) above, and the stated range covers the measured number.
By their numbers in this assay, from the lowest: compounds 3 and 2 (each within the scatter of the next); then compound 1.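

Going from 3-fluorophenyl to 2-chlorophenyl on an oxygen on a saturated carbon gives a 1.2-fold lower number from compound 2 to compound 3 (0.09 log units; within the scatter) in this assay, the first measured reading of a change at this place, and it shows that the two numbers cannot be told apart. The exchange alters both the halogen and where it is named on the phenyl ring, while the count of heavy atoms stays the same and neither group carries a hydrogen-bond donor or acceptor, so this single pair cannot separate the halogen from its location. No measurement offered here accounts for the result, so the reason for it remains unknown.

On these data alone, it remains open whether this place would respond to groups of a different kind, such as an amine or a carboxylic acid in place of the 3-fluorophenyl, or a longer chain on the same oxygen. Among these compounds, with only one step at this place, it also remains open whether the same exchange would read the same way if the trifluoromethyl-bearing phenyl elsewhere on the shared core were replaced.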